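Working notes: compound 3 to compound 4

The source may hold more compounds than are shown below. What is called first, only, known or untested is meant among the compounds shown, and "the series" means these compounds.

Of the compounds shown here, three on the shared core have been measured in a toxicity assay on HeLa cells (Homo sapiens) for inhibition; on this read-out lower numbers stand for stronger inhibition of growth and higher numbers for weaker inhibition of growth. Compound 1 `c1ccc(Nc2nc3nonc3nc2Nc2ccccc2)cc1` gives 4.4 ug/mL, compound 2 `Clc1cccc(Nc2nc3nonc3nc2Nc2cccc(Cl)c2)c1` gives 11 ug/mL, and compound 3 `FC(F)(F)Oc1cccc(Nc2nc3nonc3nc2Nc2cccc(OC(F)(F)F)c2)c1` gives 4.3 ug/mL. Compound 3 stands level with compound 1, within the scatter, while compound 2 lies beyond the scatter on the side of weaker inhibition of growth.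

Compound 4 `Cc1cccc(Nc2nc3nonc3nc2Nc2cccc(OC(F)(F)F)c2)c1` has methyl in place of trifluoromethoxy on an aromatic carbon, meta to a large group: methyl in place of trifluoromethoxy on an aromatic carbon. The other 3-(trifluoromethoxy)phenyl stays as it is. For the measured compounds named here, no measured pair differs in one place, so the size of this change has no direct precedent. Going by the values given here, the only guide is the narrow span of the measured numbers, with compound 3 at 4.3 ug/mL and compound 2 at 11 ug/mL. The expected change, a 1.2-fold higher number from compound 3 to compound 4 (0.07 log units; within the scatter), is estimated to stay within the scatter, with no firm direction. For compound 4 the estimate is 5 ug/mL, with an expected range of 2.5 ug/mL to 11 ug/mL.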

Compound 4, concentration for 50% growth inhibition: 12 ug/mL
Beside the measured number, compound 4's estimate is 2.4-fold (0.38 log units) below it; the whole stated range lies below it.
By their numbers in this assay, from the lowest: compounds 3 and 1 (each within the scatter of the next); then compounds 2 and 4 (each within the scatter of the next).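

In this assay, methyl in place of trifluoromethoxy on this aromatic carbon, meta to a large group, gives a 2.8-fold higher number from compound 3 to compound 4 (0.45 log units; beyond the scatter), which reads as weaker inhibition of growth. For the compounds shown here, this is the first change in a single place, and it shows that the group at this position can move the number beyond the scatter, although the step is modest in size and the other 3-(trifluoromethoxy)phenyl stays unchanged. No measurement at hand bears on what lies behind this step.

As far as these compounds go, it remains open whether an amine, a carboxylic acid or a longer chain at this position would stay level with compound 3 or move the number further. From the compounds shown here alone, it is also open whether the same change on the remaining 3-(trifluoromethoxy)phenyl would give a step of similar size.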